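Trifluoromethyl ketone replacing cyanopyridyl on the oxazole

This account rests on a few compounds, and the source may have more. Where it says the series, first, only, none or still open, it means among the compounds named here.

Measured so far:
compound 1 `O=C(O)c1ccc(-c2cnc(C(=O)CCc3ccc(-c4ccccc4)cc3)o2)cn1`: 44 nM
compound 2 `CS(=O)(=O)c1cnc(C(=O)CCc2ccc(-c3ccccc3)cc2)o1`: 1.2 nM
compound 3 `N#Cc1cccc(-c2cnc(C(=O)CCc3ccc(-c4ccccc4)cc3)o2)n1`: 2.9 nM

In an assay for inhibition of Fatty-acid amide hydrolase 1 (Rattus norvegicus) (a higher number here means a weaker inhibitor, a lower number a stronger inhibitor), compound 3 stands second highest of the three numbers; from compound 2 to compound 3 the change was a 2.4-fold higher number from compound 2 to compound 3 (0.38 log units; beyond the scatter), and from compound 1 to compound 3 it was a 15-fold lower number from compound 1 to compound 3 (1.18 log units; beyond the scatter). Compound 4 `O=C(CCc1ccc(-c2ccccc2)cc1)c1ncc(C(=O)C(F)(F)F)o1` differs from compound 3 by (trifluoromethyl)carbonyl in place of 6-cyanopyridin-2-yl on an aromatic carbon. The steps at this same position that bear on it are the large one a 37-fold lower number from compound 1 to compound 2 (1.56 log units; beyond the scatter) and the modest one a 2.4-fold higher number from compound 2 to compound 3 (0.38 log units; beyond the scatter); both show that a small group here gives a lower number than the cyanopyridyl or carboxypyridyl. For compound 4 a modest step lower is expected, a 1.9-fold lower number from compound 3 to compound 4 (0.29 log units; within the scatter), giving an estimated 1.5 nM with a range from 0.5 nM to 5 nM.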

Compound 4, inhibition constant: 8 nM
The estimate for compound 4 lay 5.3-fold (0.73 log units) below the measured number, outside the stated range (above it).
By their numbers in this assay, from the lowest: compound 2; then compound 3; then compound 4; then compound 1.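

In this assay, the ring-free (trifluoromethyl)carbonyl does not match the ring-bearing 6-cyanopyridin-2-yl, with a 2.8-fold higher number from compound 3 to compound 4 (0.44 log units; beyond the scatter), so losing the ring does not by itself lower the number at this position. Two ring-free groups also differ here, with a 6.7-fold higher number from compound 2 to compound 4 (0.82 log units; beyond the scatter), while the 6-carboxypyridin-3-yl remains worse, with a 5.5-fold lower number from compound 1 to compound 4 (0.74 log units; beyond the scatter). Nothing measured on these compounds explains this order. On these data alone, how a carboxylic acid or an amine placed directly on this aromatic carbon would rank remains open, as does whether a longer chain between that carbon and the carbonyl would change the number.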